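Cyclopropyl in place of hydrogen on the exocyclic amine

This account rests on a few compounds, and the source may have more. Where it says the series, first, only, none or still open, it means among the compounds named here.

Measured so far in an assay on RBL-2H3 cells for displacement of a labelled ligand from adenosine receptor A3 (Rattus norvegicus), with a stated time of 60 min; a lower number here means a stronger inhibitor, a higher number a weaker inhibitor:
compound 1 `CCCCC#Cc1nc(NCc2cccc(Cl)c2)c2ncn([C@H]3[C@H](O)[C@H](O)[C@@H]4C[C@@H]43)c2n1` gives 10.7 nM;
compound 2 `CCCCC#Cc1nc(NCc2cccc(I)c2)c2ncn([C@H]3[C@H](O)[C@H](O)[C@@H]4C[C@@H]43)c2n1` gives 26 nM;
compound 3 `CCCCC#Cc1nc(N)c2ncn([C@H]3[C@H](O)[C@H](O)[C@@H]4C[C@@H]43)c2n1` gives 65 nM.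

Among these three, compound 3 carries the highest number, that is, it is the weakest inhibitor; its steps to compound 2 and compound 1 are both beyond the scatter.

Compound 4 `CCCCC#Cc1nc(NC2CC2)c2ncn([C@H]3[C@H](O)[C@H](O)[C@@H]4C[C@@H]43)c2n1` differs from compound 3 by cyclopropyl in place of hydrogen on a nitrogen on an aromatic ring, the same difference, cut one bond further out, reading amino to cyclopropylamino.

Among the compounds with values here, two measured steps bear on this: a 6.1-fold higher number from compound 1 to compound 3 (0.78 log units; beyond the scatter) and a 2.5-fold higher number from compound 2 to compound 3 (0.40 log units; beyond the scatter). Within the data shown here, both show that a group on that nitrogen goes with a lower number than hydrogen, though cyclopropyl is smaller than either benzyl group and no measured compound shows it. A modest lower number is therefore expected for compound 4, as a 2.2-fold lower number from compound 3 to compound 4 (0.34 log units; beyond the scatter), giving an estimate of 30 nM with a range of 10 nM to 90 nM.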

Compound 4, inhibition constant: 39 nM
Beside the measured number, compound 4's estimate is 1.3-fold (0.11 log units) below it, and the stated range covers the measured number.
By their numbers in this assay, from the lowest: compound 1; then compounds 2, 4 and 3 (each within the scatter of the next, the first and the last beyond it).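

In this assay, cyclopropyl on this nitrogen cannot be told apart from hydrogen (a 1.7-fold lower number from compound 3 to compound 4 (0.22 log units; within the scatter)), so adding a group here does not by itself give a clear gain. It also cannot be told apart from 3-iodobenzyl (a 1.5-fold higher number from compound 2 to compound 4 (0.18 log units; within the scatter)), whereas 3-chlorobenzyl keeps a clear lead (a 3.6-fold higher number from compound 1 to compound 4 (0.56 log units; beyond the scatter)). No evidence is available to explain these numbers.

The compounds shown leave open how a plain benzyl group or a straight propyl chain on this nitrogen would compare. The gap to compound 1 therefore cannot yet be tied to either the aromatic ring or the chloro group.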